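This account rests on a few compounds, and the source may have more. Where it says the series, first, only, none or still open, it means among the compounds named here.

Compound 1 `O=C(NCc1cc(C(F)(F)F)nn1-c1ccc(C(F)(F)F)cc1)Nc1cccc2[nH]ncc12` in an assay on CHO-K1 cells for antagonist activity at transient receptor potential cation channel subfamily V member 1 (Homo sapiens), read by FLIPR and calcium flux, with a stated time of 6 min (on this read-out higher numbers stand for weaker inhibition and lower numbers for stronger inhibition), gives 3.8 nM.
Compound 2 `CC(C)(C)c1cc(CNC(=O)Nc2cccc3[nH]ncc23)n(-c2ccc(F)cc2)n1` gives 2.2 nM.
Compound 3 `CC(C)(C)c1cc(CNC(=O)Nc2cccc3[nH]ncc23)n(-c2ccc(C(F)(F)F)cc2)n1` gives 19.6 nM.

Compound 3 stands highest of the three numbers, with a 5.2-fold higher number from compound 1 to compound 3 (0.71 log units; beyond the scatter) and an 8.9-fold higher number from compound 2 to compound 3 (0.95 log units; beyond the scatter) both beyond the scatter. Compound 4 `Cn1ncc2c(NC(=O)NCc3cc(C(C)(C)C)nn3-c3ccc(C(F)(F)F)cc3)cccc21` differs from compound 3 by methyl in place of hydrogen on an aromatic nitrogen. Neither measured step touches this part of the shared core: both concern groups on the aromatic carbons, not the ring nitrogen, so nothing here bears on the change. The step expected here is estimated as a 2.0-fold higher number from compound 3 to compound 4 (0.31 log units; beyond the scatter), and the range around that estimate is wide. The estimate for compound 4 in this assay is 40 nM, between 8 nM and 200 nM.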

Compound 4, inhibition constant: 12.4 nM
For compound 4 the middle estimate is 3.2-fold (0.51 log units) above the measured one, and the stated range covers the measured number.
By their numbers in this assay, from the lowest: compounds 2 and 1 (each within the scatter of the next); then compounds 4 and 3 (each within the scatter of the next).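

In this assay, methyl in place of hydrogen on an aromatic nitrogen gives a 1.6-fold lower number from compound 3 to compound 4 (0.20 log units; within the scatter). Among the compounds shown here, the earlier steps concerned only groups on aromatic carbons, so this is the first reading at the ring nitrogen, and here the hydrogen can be exchanged for methyl with no step beyond the scatter. Nothing available accounts for this result. As far as these compounds go, whether an ethyl group or a longer chain ending in an amine on this nitrogen reads the same remains open. So does whether methyl reads alike in compound 1 and compound 2, which carry other groups.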